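The compounds below may be only part of what the source reports. "The series", "measured", "known", "first", "only" and "open" are said of these compounds alone.

Measured compounds in the series:

- compound 1, `COc1cc(NC(=O)Nc2ccccc2)cc(OC)c1OC`, a functional assay on ONS-76 cells (Homo sapiens) for cytotoxicity, read by MTT assay, with a stated time of 72 h; a lower number here means a stronger inhibitor, a higher number a weaker inhibitor: "not determined" (no result reported)
- compound 2, `COc1cc(NC(=O)Nc2cccc3cc(O)ccc23)cc(OC)c1OC`, this assay: >= 125000 nM
- compound 3, `COc1cc(NC(=O)Nc2cccc([N+](=O)[O-])c2)cc(OC)c1OC`, this assay: 79600 nM

Compound 1 carries the shared core with an unsubstituted phenyl ring on the urea. In this assay compound 1 has no number of its own, so it stands nowhere on the scale shown; its result is given only as "not determined" (no result reported). For compound 2 this assay reports only a limit, >= 125000 nM, and not a number. Compound 3 gives 79600 nM in this assay. Going by the values given here, of the three results, one sits at the limit of >= 125000 nM in this assay, at which 1 of the 3 values shown sits, and the one real number is itself weak. Among the compounds with values here, no pair of measured compounds differs in a single place, so no measured step is available; the two values only show that the series as a whole is a weak inhibitor in this assay.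

Compound 4, `COc1cc(NC(=O)Nc2ccc(F)cc2)cc(OC)c1OC`, differs from compound 1 by fluoro in place of hydrogen on an aromatic carbon. Within the data shown here, with no numeric anchor for compound 1 and no measured step to draw on, no size or direction of change beyond the scatter can be expected; the expectation rests on the weak values of compound 2 and compound 3. Compound 4 is therefore estimated at 90000 nM, with a range from 30000 nM to 250000 nM, and a fair chance that this assay reports only a limit.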

Compound 4, half-maximal inhibitory concentration: 63300 nM
Compound 4: the middle estimate sits 1.4-fold (0.15 log units) above what was measured; the measured number falls inside the stated range.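

No step can be read from compound 1 to compound 4: in this assay compound 1 is recorded as "not determined" (no result reported), while compound 4 gives 63300 nM. The compounds shown leave open whether phenyl to 4-fluorophenyl shifts the value in this assay at all, and what any single change on the shared core does.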